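The compounds below may be only part of what the source reports. "The series", "measured", "known", "first", "only" and "open" are said of these compounds alone.

Compound 1 `COc1ccc(C(=O)/C=C/c2ccccn2)c2c1C=CC(C)(C)O2` and compound 2 `COc1ccc(C(=O)/C=C/c2cccs2)c2c1C=CC(C)(C)O2` share one core and differ only in the ring on the double-bonded chain carbon. In a functional assay on HT-29 cells (Homo sapiens) for antiproliferative activity, read by MTT assay, with a stated time of 24 h (on this read-out higher numbers stand for weaker inhibition and lower numbers for stronger inhibition), compound 1 gives 2120 nM. In this assay compound 2 gives only a limit, > 10000 nM, so no number is known for it. The step of an at least 4.7-fold higher number from compound 1 to compound 2 (0.67 log units; beyond the scatter) is the only measured one, and its size is bounded by the limit of > 10000 nM in this assay, at which 1 of the 2 values shown sits. Compound 3 `COc1ccccc1/C=C/C(=O)c1ccc(OC)c2c1OC(C)(C)C=C2` carries instead (2-methoxyphenyl in place of thiophen-2-yl on a double-bonded chain carbon bound to a double-bonded chain carbon). Within the data shown here, no measured step involves a 2-methoxyphenyl, so the expectation for compound 3 rests on the fact that compound 2 sits at the limit while compound 1 gives a number; a step back toward the number of compound 1 is expected, an at least 1.2-fold lower number from compound 2 to compound 3 (0.09 log units; that floor lies within the scatter), though its size is uncertain. Compound 3 is therefore estimated at 8000 nM, in a range from 2000 nM to 30000 nM.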

Compound 3, half-maximal inhibitory concentration: > 10000 nM
Compound 3 was reported as a limit (the forecaster's own chance of this, stated with the estimate: 45%); at least 1.2-fold (0.09 log units) between middle value and limit.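

At this place, on a double-bonded chain carbon bound to a double-bonded chain carbon, a six-membered aromatic ring of carbon only now also fails to give a number: in this assay, 2-methoxyphenyl in place of pyridin-2-yl gives an at least 4.7-fold higher number from compound 1 to compound 3 (0.67 log units; beyond the scatter). Of the three rings shown, only the pyridin-2-yl of compound 1 gives a number, so this change, like thiophen-2-yl before it, costs activity, and nothing among the three goes against that. The step between compound 2 and compound 3 cannot be read, and the comparison stops at a shared limit: the limit of > 10000 nM in this assay, at which 2 of the 3 values shown sit.

The compounds shown leave open whether the ring nitrogen of pyridin-2-yl matters here. They also leave open how a pyridin-4-yl or a phenyl carrying a dimethylamino group would compare with compound 1 at 2120 nM.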